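The source may report more compounds than this note shows. Statements on the series, on what has been measured and on what is new or still open speak of the compounds shown alone.

In a physicochemical assay for solubility, read by nephelometry, measured as kinetic solubility, at pH 2.0 (on this read-out lower numbers stand for lower solubility and higher numbers for higher solubility), compound 1 `NCc1csc(NC(=O)c2ccon2)n1` gives 50 ug/mL as a measured number. Compound 2 `NCc1csc(NC(=O)c2ccn[nH]2)n1` gives > 100 ug/mL as a limit of the assay and not a number. The change to compound 3 `NCc1csc(NC(=O)c2cnn[nH]2)n1` puts 1H-1,2,3-triazol-5-yl in place of 1H-pyrazol-5-yl on a carbonyl carbon, and in counts it reads 1H-1,2,3-triazol-5-yl in place of 1H-pyrazol-5-yl on a carbonyl carbon with the place unchanged. For the measured compounds named here, the one measured step on such a carbonyl carbon is an at least 2.0-fold higher number from compound 1 to compound 2 (0.30 log units; that floor lies within the scatter) and it involves a different swap, so no shift beyond the usual scatter is expected in this assay here. The expected result is a step that the limit leaves unreadable from compound 2 to compound 3 and no more. Compound 3 is estimated at 110 ug/mL with an expected range from 50 ug/mL to 200 ug/mL in this measurement.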

Compound 3, solubility: > 100 ug/mL
Compound 3 ended at the assay's limit (the forecaster's own chance of this, stated with the estimate: 60%); the middle value lies beyond the limit too.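

Compound 3 shows that a ring with 3 hetero atoms on this carbonyl carbon also reaches the assay's limit, as the ring with 2 hetero atoms in compound 2 did. In this assay, 1H-1,2,3-triazol-5-yl in place of 1,2-oxazol-3-yl gives an at least 2.0-fold higher number from compound 1 to compound 3 (0.30 log units; that floor lies within the scatter). The step from compound 2 to compound 3 cannot be read, because both values are limits and not numbers: the limit of > 100 ug/mL in this assay, at which 2 of the 3 values shown sit.

From the compounds shown here alone, the true solubilities of compound 2 and compound 3 remain open. So does how a phenyl ring or a 1H-tetrazol-5-yl group on this carbonyl carbon would read in this assay.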